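Aryl piperazine fluorine removed from compound 1

The source may hold more compounds than are shown below. What is called first, only, known or untested is meant among the compounds shown, and "the series" means these compounds.

Compound 1 `CS(=O)(=O)c1ccc(C(=O)N2CCC(C(=O)N3CCN(c4ccc(F)cc4)CC3)CC2)cc1[N+](=O)[O-]` gives > 60000 nM in an assay on isolated protein for inhibition of vitamin D3 receptor (Homo sapiens), read by fluorescence polarization (a lower number here means a stronger inhibitor, a higher number a weaker inhibitor), which is a limit of the assay.
Compound 2 `CN(Cc1cccc(F)c1)C(=O)CCCNC(=O)c1ccc(S(C)(=O)=O)c([N+](=O)[O-])c1` gives > 60000 nM in this assay, likewise a limit.

Compound 1 thus sits at the limit of > 60000 nM in this assay, at which 2 of the 2 values shown sit. No number separates compound 1 from compound 2. Compound 3 `CS(=O)(=O)c1ccc(C(=O)N2CCC(C(=O)N3CCN(c4ccccc4)CC3)CC2)cc1[N+](=O)[O-]` differs from compound 1 by hydrogen in place of fluoro on an aromatic carbon. Among the compounds with values here, no step between measured compounds is available. For compound 3 the expected change in this assay against compound 1 is none beyond the scatter, most likely again a limit. Compound 3 is estimated at 100000 nM, with a range from 30000 nM to 300000 nM. The estimated step is a step that the limit leaves unreadable from compound 1 to compound 3.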

Compound 3, half-maximal inhibitory concentration: > 60000 nM
Compound 3: only a limit was reported (the forecaster's own chance of this, stated with the estimate: 85%); the middle value is on the limit's open side.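

No step can be read from compound 1 to compound 3, because both values are limits of the assay: the limit of > 60000 nM in this assay, at which 3 of the 3 values shown sit.

The compounds shown leave open how 4-fluorophenyl and phenyl compare in this assay, and how strongly any of these compounds inhibits there.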